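Furan-3-yl entering on the chain of compound 1

This account rests on a few compounds, and the source may have more. Where it says the series, first, only, none or still open, it means among the compounds named here.

compound 1 `CC(=O)O[C@@H]1C[C@@H](C)[C@](O)(CCC2=CC(=O)OC2)[C@@]2(C)CCCC(C)(C)[C@H]12`: < 5 ug/mL, a limit of the assay
compound 2 `C[C@@H]1C[C@@H](O)[C@H]2C(C)(C)CCC[C@]2(C)[C@@]1(O)CCC1=CC(=O)OC1`: < 5 ug/mL, a limit of the assay
compound 3 `C[C@@H]1CC=C2C(C)(C)CCC[C@]2(C)[C@@]1(O)CCC1=CC(=O)OC1`: < 5 ug/mL, a limit of the assay

In a functional assay on HL-60 cells (Homo sapiens) for cytotoxicity, read by MTT assay, with a stated time of 72 h (a lower number here means a stronger inhibitor, a higher number a weaker inhibitor), compound 1 stands at a limit and not at a number; so do the other two, as the limit of < 5 ug/mL in this assay, at which 3 of the 3 values shown sit, shows. Among the measured compounds shown here, the one step between measured compounds, a step that the two limits leave unreadable from compound 1 to compound 2, is therefore of unreadable size. Compound 4 `CC(=O)O[C@@H]1C[C@@H](C)[C@](O)(CCc2ccoc2)[C@@]2(C)CCCC(C)(C)[C@H]12` differs from compound 1 by a group of 5 heavy atoms (4 carbon, 1 oxygen; one five-membered aromatic ring with 1 hetero atom) in place of a group of 6 heavy atoms (4 carbon, 2 oxygen; one five-membered non-aromatic ring with 1 hetero atom), on a saturated chain carbon, two bonds along the chain from a saturated ring carbon. No measured step touches this group, so the size of the step to compound 4 cannot be anchored on the numbers shown, and the limits allow either direction. Compound 4 is expected at 6 ug/mL, between 1.5 ug/mL and 25 ug/mL. This expectation means an at least 1.2-fold higher number from compound 1 to compound 4 (0.07 log units; that floor lies within the scatter), carried with little weight.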

Compound 4, half-maximal inhibitory concentration: < 5 ug/mL
Compound 4: a limit, no number; the forecaster's own chance of this, stated with the estimate: 35%; middle value at least 1.2-fold (0.07 log units) from the limit.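

No step can be read from compound 1 to compound 4, because both values are limits: the limit of < 5 ug/mL in this assay, at which 4 of the 4 values shown sit.

The compounds shown leave open whether furan-3-yl and the group it replaces differ at all in this assay, and how the four compounds rank.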